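Amide nitrogen substituent swap across two cores

The source may hold more compounds than are shown below. What is called first, only, known or untested is meant among the compounds shown, and "the series" means these compounds.

Compound 1 `COc1ncc(-c2ccc3c(c2)N(c2ccc(C)cc2)C(=O)CO3)cc1NS(=O)(=O)c1ccc(F)cc1` gives 4650 nM in a functional assay on HeLa cells (Homo sapiens) for antiproliferative activity, read by MTT assay, with a stated time of 72 h; on this read-out lower numbers stand for stronger inhibition and higher numbers for weaker inhibition. Compound 2 `COc1ncc(-c2ccc3c(c2)N(C2CCCCC2)C(=O)CO3)cc1NS(=O)(=O)c1ccc(F)cc1` gives 6100 nM in this assay. The change between them is 4-methylphenyl in place of cyclohexyl on an amide-type nitrogen in a ring and makes a step of a 1.3-fold lower number from compound 2 to compound 1 (0.12 log units; within the scatter). Compound 3 `O=C1COc2ccc(-c3cnc4ccccc4c3)cc2N1C1CCCCC1` gives 19700 nM in this assay, the highest of the three numbers; the difference between its core and that of compound 2 is not broken down here. Compound 4 `Cc1ccc(N2C(=O)COc3ccc(-c4cnc5ccccc5c4)cc32)cc1`, not yet measured, differs from compound 3 by 4-methylphenyl in place of cyclohexyl on an amide-type nitrogen in a ring, the same change as that from compound 2 to compound 1, at a place described in identical words. The expected step of a 1.3-fold lower number from compound 3 to compound 4 (0.12 log units; within the scatter) is set beside the earlier one and rests on compound 2 to compound 1 giving a 1.3-fold lower number from compound 2 to compound 1 (0.12 log units; within the scatter), a change inside the scatter. For compound 4 the estimate in this assay is 15000 nM, with a range from 7000 nM to 35000 nM, because compound 3 stands at 19700 nM.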

Compound 4, half-maximal inhibitory concentration: > 40000 nM
Compound 4 gave a limit, no number; the forecaster's own chance of this, stated with the estimate: 10%; at least 2.6-fold (0.42 log units) between middle value and limit.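

Compound 4 stands at > 40000 nM in this assay, which is a limit of the assay and not a number. On the core of compound 3, 4-methylphenyl in place of cyclohexyl gives an at least 2.0-fold higher number from compound 3 to compound 4 (0.30 log units; that floor lies within the scatter). Set beside the earlier step, the result reads: the same change on two cores in this assay, a 1.3-fold lower number (0.12 log units; within the scatter) from compound 2 to compound 1 and an at least 2.0-fold higher number (0.30 log units; that floor lies within the scatter) from compound 3 to compound 4; the limit leaves it open whether they differ

The change therefore cannot be said either to carry over between the two cores or to depend on the core, as one pair gives a number and the other only a floor.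

The compounds shown place only cyclohexyl and 4-methylphenyl on that nitrogen. Open, as far as these compounds go, is whether a chain ending in an amine or a carboxylic acid there would give measurable numbers on both cores, and so steps that can be compared.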